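Methylation of the amine nitrogen of compound 1

A few compounds are considered here, and "the series" means these few. Any claim that something is new, unique, unknown or untested is made for them only; others in the source may bear on it.

Measured so far:
- compound 1 `CNCC(=O)Nc1cc(OC)ccc1C(=O)c1cc(OC)c(OC)c(OC)c1` gives 580 nM
- compound 2 `C=C(c1ccc(OC)cc1NC(=O)CO)c1ccc(OC)c2c1OC(C)(C)C=C2` gives 40 nM

Within the data shown here, both values come from a functional assay on A2780 cells (Homo sapiens) for antiproliferative activity, read by MTT assay, with a stated time of 48 h (a lower number here means a stronger inhibitor, a higher number a weaker inhibitor), and are the only measurements available for the series. Compound 1 stands at the higher of the two numbers, so it is the weaker inhibitor of the pair. The gap down to compound 2 lies beyond the scatter. The two compounds differ in more than one place, so this gap says nothing about any single structural change.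

The next compound to be measured is compound 3 `COc1ccc(C(=O)c2cc(OC)c(OC)c(OC)c2)c(NC(=O)CN(C)C)c1`, which carries methyl in place of hydrogen on an amine nitrogen. In this change, methylamino becomes dimethylamino and the rest of the structure stays the same. Among the measured compounds shown here, no measured pair shows this change, or any other single change, so neither its size nor its direction can be read from the data. The expectation in this assay is therefore anchored on compound 1 at 580 nM, with no shift beyond the scatter and no firm direction. The expected change is a 1.2-fold higher number from compound 1 to compound 3 (0.08 log units; within the scatter) and remains an estimate resting on one close analogue. Compound 3 is expected at 700 nM, with an estimated range from 200 nM to 2500 nM.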

Compound 3, half-maximal inhibitory concentration: 580 nM
Compound 3: the middle estimate sits 1.2-fold (0.08 log units) above what was measured; low and high end bracket the measured number.
By their numbers in this assay, from the lowest: compound 2; then compounds 1 and 3 (each within the scatter of the next).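

In this assay, among these compounds, methyl in place of hydrogen on the amine nitrogen gives no change at the digits printed from compound 1 to compound 3 (within the scatter), the first single change that can be read on its own. At this position, on an amine nitrogen whose other neighbours are saturated chain carbons, methylamino and dimethylamino therefore read alike, so the hydrogen on this nitrogen is not needed to hold the number in this assay on the core of compound 1. No measurement at hand bears on why the two compounds read alike.

Among the compounds shown here, this single step covers only one swap at one place, so it leaves open how the series responds to an unsubstituted amine, to ethyl on the same nitrogen, or to a morpholine ring in place of dimethylamino. Going by these compounds, whether methyl on this nitrogen would read the same way on another core also stays open, and compound 2 cannot settle that, since it differs from compound 1 in more than one place.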